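The source may hold more compounds than are shown below. What is called first, only, known or untested is meant among the compounds shown, and "the series" means these compounds.

The measured compounds:
compound 1, `Fc1ccccc1Nc1nc2nonc2nc1NC1CCCCC1`, gives 13400 nM
compound 2, `COc1cccc(Nc2nc3nonc3nc2Nc2ccccc2F)c1`, gives 830 nM

These values come from an assay on mitochondria from L6 cells (Rattus norvegicus) for activation, with a stated time of 90 min; a higher number here means that more compound is needed for the effect, a lower number that less compound is needed. Among the measured compounds shown here, compound 2 stands lowest of the two numbers measured, with compound 1 the only neighbour, reached through a 16-fold lower number from compound 1 to compound 2 (1.21 log units; beyond the scatter). Compound 3, `CCOc1ccccc1Nc1nc2nonc2nc1Nc1ccccc1F`, has not yet been measured; it differs from compound 2 by 2-ethoxyphenyl in place of 3-methoxyphenyl on a nitrogen on an aromatic ring.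

For the measured compounds named here, the single measured step, a 16-fold lower number from compound 1 to compound 2 (1.21 log units; beyond the scatter), bears on the same nitrogen, but it exchanged a saturated ring for an aromatic one. The change to compound 3 keeps the aromatic ring and only alters the alkoxy group on it, so that step gives no direct guide to direction. In this assay the expected outcome is therefore a step not clearly beyond the scatter, with a wide range to reflect the uncertainty. Compound 3 is estimated at 1200 nM, between 350 nM and 4500 nM, which would mean a step of a 1.4-fold higher number from compound 2 to compound 3 (0.16 log units; within the scatter).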

Compound 3, half-maximal effective concentration: 5600 nM
Beside the measured number, compound 3's estimate is 4.7-fold (0.67 log units) below it; the measured number lies above the stated range.
By their numbers in this assay, from the lowest: compound 2; then compound 3; then compound 1.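

In this assay, having an aromatic ring on this nitrogen is not the whole story: a 6.7-fold higher number from compound 2 to compound 3 (0.83 log units; beyond the scatter) shows that the number also depends on what the ring carries, even though 3-methoxyphenyl and 2-ethoxyphenyl are closely related groups. Compound 3 keeps only part of the gain seen with compound 2, and a 2.4-fold lower number from compound 1 to compound 3 (0.38 log units; beyond the scatter) places 2-ethoxyphenyl ahead of cyclohexyl by a smaller margin. No measurement shown here explains the difference between the two aromatic groups.

2-Ethoxyphenyl differs from 3-methoxyphenyl both in where the alkoxy group sits on the ring and in the length of its chain, so it remains open which of these changes drives the step; 2-methoxyphenyl or 3-ethoxyphenyl would separate them. From the compounds shown here alone, how a ring carrying an amine or a carboxylic acid instead would behave in this assay also remains open.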